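The source may report more compounds than this note shows. Statements on the series, on what has been measured and on what is new or still open speak of the compounds shown alone.

Compound 2 `CC(C)/N=C(\S)OC[C@H]1OC(n2cnc3c(NC4CCOC4)ncnc32)[C@H](O)[C@@H]1O` gives 36 nM in an assay on DDT1 cells (Cricetulus griseus) for binding affinity to adenosine receptor A1 (Homo sapiens), read by radioligand binding (a lower number here means a stronger inhibitor, a higher number a weaker inhibitor), the lowest of the two numbers shown; compound 1 `CCCCNC(=O)OC[C@H]1OC(n2cnc3c(NC4CCOC4)ncnc32)[C@H](O)[C@@H]1O` gives 1410 nM in this assay. Compound 3 `O=C(NC1CCCCC1)OC[C@H]1OC(n2cnc3c(NC4CCOC4)ncnc32)[C@H](O)[C@@H]1O` differs from compound 2 by a group of 9 heavy atoms (7 carbon, 1 nitrogen, 1 oxygen; one six-membered non-aromatic ring of carbon only) in place of a group of 6 heavy atoms (4 carbon, 1 nitrogen, 1 sulfur; no ring), on an oxygen on a saturated carbon. Within the data shown here, the one measured step that bears on this is a 39-fold lower number from compound 1 to compound 2 (1.59 log units; beyond the scatter), which moved from a carbamate to the group that now leaves. Since compound 3 returns to a carbamate, much of that gain is expected to be given back, so compound 3 is expected to show a 14-fold higher number from compound 2 to compound 3 (1.14 log units; beyond the scatter). Compound 3 is therefore estimated at 500 nM, with a range from 150 nM to 2000 nM.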

Compound 3, inhibition constant: 584 nM
Estimate against measurement, compound 3: 1.2-fold (0.07 log units) below; measured number inside the range.
By their numbers in this assay, from the lowest: compound 2; then compound 3; then compound 1.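

Among the carbamates, cyclohexyl in place of butyl on the amide-type nitrogen gives only a 2.4-fold lower number from compound 1 to compound 3 (0.38 log units; beyond the scatter) while leaving the sulfur-bearing group for cyclohexylcarbamoyl gives a 16-fold higher number from compound 2 to compound 3 (1.21 log units; beyond the scatter). At this oxygen on a saturated carbon, this assay thus responds less to the change on the carbamate nitrogen than to the change that removes the sulfur-bearing group. Nothing available here explains this difference. Going by these compounds, it remains open whether a thiocarbamate carrying cyclohexyl on the nitrogen would match the low number of compound 2, and how a urea would read at this place.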